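The source may report more compounds than this note shows. Statements on the series, on what has been measured and on what is new or still open speak of the compounds shown alone.

Measured in a functional assay on SMMC-7721 cells (Homo sapiens) for antiproliferative activity, read by MTT assay, with a stated time of 48 h; a higher number here means a weaker inhibitor, a lower number a stronger inhibitor:
- Compound 1 `Cn1cc(C2=C(c3nn(CCCn4cncn4)c4ncccc34)C(=O)N(c3ccccc3)C2=O)c2ccccc21`: > 100000 nM, a limit
- Compound 2 `Cn1cc(C2=C(c3nn(CCCn4cccc4)c4ncccc34)C(=O)NC2=O)c2ccccc21`: > 100000 nM, a limit
- Compound 3 `Cn1cc(C2=C(c3nn(CCCn4ccnc4)c4ncccc34)C(=O)N(c3ccccc3)C2=O)c2ccccc21`: 34800 nM

Compound 3, at 34800 nM, is the only one of the three with an actual number. The values of compound 1 and compound 2 are limits. Compound 4 `Cn1cc(C2=C(c3nn(CCCn4cccc4)c4ncccc34)C(=O)N(c3ccccc3)C2=O)c2ccccc21` carries 1H-pyrrol-1-yl in place of the 1H-imidazol-1-yl of compound 3, on a saturated chain carbon, three bonds along the chain from an aromatic nitrogen: 1H-pyrrol-1-yl in place of 1H-imidazol-1-yl on a saturated chain carbon, three bonds along the chain from an aromatic nitrogen.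

Within the data shown here, one measured step bears directly on this place. It is an at least 2.8-fold lower number from compound 1 to compound 3 (0.45 log units; beyond the scatter), where 1H-imidazol-1-yl stands in place of 1H-1,2,4-triazol-1-yl. Its size is only a lower bound, since one end of it is a limit. Compound 2 also carries 1H-pyrrol-1-yl, but it differs from compound 4 elsewhere in the structure, so it gives no clean comparison.

Given an at least 2.8-fold lower number from compound 1 to compound 3 (0.45 log units; beyond the scatter), moving away from 1H-imidazol-1-yl is expected to shift the number upward in this assay, though perhaps not beyond the scatter. The expected step is a 1.4-fold higher number from compound 3 to compound 4 (0.16 log units; within the scatter). For compound 4 the estimate is 50000 nM, with an expected range of 18000 nM to 100000 nM.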

Compound 4, half-maximal inhibitory concentration: > 100000 nM
Compound 4 was reported as a limit (the forecaster's own chance of this, stated with the estimate: 40%); middle value at least 2.0-fold (0.30 log units) away from the limit.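

In this assay, replacing 1H-imidazol-1-yl with 1H-pyrrol-1-yl at the end of the 3-carbon-named propyl chain gives an at least 2.8-fold higher number from compound 3 to compound 4 (0.45 log units; beyond the scatter), so this position now has a readable step on the pyrrole side as well as on the triazole side. Compound 4 gives > 100000 nM, which is a limit, so this step, like an at least 2.8-fold lower number from compound 1 to compound 3 (0.45 log units; beyond the scatter), fixes only a lower bound on its size. Among the compounds carrying phenyl on the amide-type nitrogen, 1H-imidazol-1-yl is thus the only ring on this chain that gives a number rather than a limit, and the series as a whole is dominated by that limit: the limit of > 100000 nM in this assay, at which 3 of the 4 values shown sit.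

As far as these compounds go, the steps from compound 2 to compound 4 and from compound 1 to compound 4 cannot be read, each having a limit at both ends, so the effect of the phenyl on the amide-type nitrogen and any order between 1H-pyrrol-1-yl and 1H-1,2,4-triazol-1-yl remain unknown. Also open, from the compounds shown here alone, is how a dimethylamino group, a morpholine ring or a longer chain would read at this place.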